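The compounds below may be only part of what the source reports. "The series", "measured", "known", "first", "only" and "open" are said of these compounds alone.

Measured so far in a functional assay on A2780 cells (Homo sapiens) for inhibition, read by MTT assay, with a stated time of 72 h; on this read-out lower numbers stand for stronger inhibition of growth and higher numbers for weaker inhibition of growth:
- compound 1 `O=S(=O)(NCCCNCc1ccccc1Cl)c1cc(C(F)(F)F)cc(C(F)(F)F)c1` gives 9300 nM
- compound 2 `CN(CCCNS(=O)(=O)c1cc(C(F)(F)F)cc(C(F)(F)F)c1)Cc1ccccc1` gives 28000 nM
- compound 3 `O=S(=O)(NCCCNCc1cccc2ccccc12)c1cc(C(F)(F)F)cc(C(F)(F)F)c1` gives 3100 nM

Compound 3 has the lowest number of the three. Among the compounds with values here, its nearest neighbour is compound 1, and the single step of a 3.0-fold lower number from compound 1 to compound 3 (0.48 log units; beyond the scatter) separates them; compound 2 lies furthest away, and the step of a 3.0-fold higher number from compound 1 to compound 2 (0.48 log units; beyond the scatter) accounts for part of that gap.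

Compound 4 `COc1ccccc1CNCCCNS(=O)(=O)c1cc(C(F)(F)F)cc(C(F)(F)F)c1` is not yet measured. Relative to compound 3 the change is 2-methoxyphenyl in place of naphthalen-1-yl on a saturated chain carbon bound to an amine nitrogen. The step that bears on it is a 3.0-fold lower number from compound 1 to compound 3 (0.48 log units; beyond the scatter), since compound 4 returns from the two-ring group to a single ring carrying one substituent, as compound 1 does, though with a methoxy group instead of a chlorine. Within the data shown here, no measured step separates a 2-methoxy from a 2-chloro substituent, so the expectation rests on compound 1 alone. Compound 4 is therefore expected to move back toward the number of compound 1, with the step of a 3.2-fold higher number from compound 3 to compound 4 (0.51 log units; beyond the scatter) estimated. For compound 4 the estimated value is 10000 nM, within a range from 4000 nM to 25000 nM.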

Compound 4, concentration for 50% growth inhibition: 1500 nM
Beside the measured number, compound 4's estimate is 6.7-fold (0.82 log units) above it; the measured number lies below the stated range.
By their numbers in this assay, from the lowest: compound 4; then compound 3; then compound 1; then compound 2.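

In this assay, the step of a 2.1-fold lower number from compound 3 to compound 4 (0.32 log units; beyond the scatter) shows that a single ring carrying a methoxy group, 2-methoxyphenyl, can outdo the two-ring naphthalen-1-yl on a saturated chain carbon bound to an amine nitrogen, so a second ring is not required at this place. The step of a 6.2-fold lower number from compound 1 to compound 4 (0.79 log units; beyond the scatter) shows that the single ring's substituent matters, with methoxy in place of chloro on an aromatic carbon giving a change beyond the scatter. The step of a 19-fold lower number from compound 2 to compound 4 (1.27 log units; beyond the scatter) is the largest in the series, but it exchanges the nitrogen's methyl group and adds the methoxy together, so it does not apportion the change between them.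

On these data alone, it remains open how an ethoxy or hydroxyl group on the ring, or a longer chain, would read in this assay. Nothing available gives a reason for these steps.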